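Swapping the Aryl Group on the Imine: Expected Tolerance of Compound 4

The source may report more compounds than this note shows. Statements on the series, on what has been measured and on what is new or still open speak of the compounds shown alone.

Compound 1 `Fc1ccccc1/C=N/c1sc2c(c1-c1nc3ccccc3s1)CCCC2` gives 398 ug/mL in an ADME assay on HepG2 cells (Homo sapiens) for cytotoxicity, read by MTT assay, with a stated time of 72 h; a higher number here means that more compound is tolerated, a lower number that less compound is tolerated.
Compound 2 `Clc1ccccc1/C=N/c1sc2c(c1-c1nc3ccccc3s1)CCCC2` gives 370 ug/mL in this assay.
Compound 3 `O=[N+]([O-])c1ccc(/C=N/c2sc3c(c2-c2nc4ccccc4s2)CCCC3)cc1` gives 454 ug/mL in this assay.

All three numbers lie within the scatter of one another, so compound 3 is not set apart: its step from compound 1 is a 1.1-fold higher number from compound 1 to compound 3 (0.06 log units; within the scatter) and from compound 2 is a 1.2-fold higher number from compound 2 to compound 3 (0.09 log units; within the scatter). Compound 4 `Oc1ccccc1/C=N/c1sc2c(c1-c1nc3ccccc3s1)CCCC2` differs from compound 3 in one place: 2-hydroxyphenyl in place of 4-nitrophenyl on a carbon with a double bond to nitrogen. For the measured compounds named here, the steps that bear on this change are the two aryl exchanges just given, both within the scatter, alongside a 1.1-fold lower number from compound 1 to compound 2 (0.03 log units; within the scatter). Going by the values given here, no measured step tests a hydroxyphenyl group, so the expectation rests on those steps alone, and no step beyond the scatter is expected in this assay. Compound 4 is therefore estimated at 400 ug/mL, between 250 ug/mL and 640 ug/mL, meaning an expected 1.1-fold lower number from compound 3 to compound 4 (0.05 log units; within the scatter).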

Compound 4, half-maximal cytotoxic concentration: 114 ug/mL
Compound 4: middle estimate off by 3.5-fold (0.55 log units), on the high side, outside the stated range (below it).
By their numbers in this assay, from the lowest: compound 4; then compounds 2, 1 and 3 (each within the scatter of the next).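

Earlier exchanges on the aryl group at this carbon stayed within the scatter, but 2-hydroxyphenyl brings steps beyond it in this assay (a 4.0-fold lower number from compound 3 to compound 4 (0.60 log units; beyond the scatter)). Hydroxy in place of either halogen on an aromatic carbon also gives a step beyond the scatter (a 3.2-fold lower number from compound 2 to compound 4 (0.51 log units; beyond the scatter); a 3.5-fold lower number from compound 1 to compound 4 (0.54 log units; beyond the scatter)), so this position can respond to a single change of group. No measurement here gives a reason for these steps. On these data alone, whether a methoxy group or an amine in place of the hydroxy group would give a step of this size stays open.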